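Cytotoxicity notes: hexylsulfanyl in place of trifluoroethoxy

The compounds below may be only part of what the source reports. "The series", "measured", "known", "first", "only" and "open" are said of these compounds alone.

In an ADME assay on Akata cells (Homo sapiens) for cytotoxicity, with a stated time of 7 days (on this read-out lower numbers stand for higher toxicity in this test and higher numbers for lower toxicity in this test), compound 2 `Nc1nc(OCC(F)(F)F)c2ncn(/C=C3/CC3(CO)CO)c2n1` gives only a limit, > 20000 nM. Compound 1 `CNc1nc(N)nc2c1ncn2/C=C1/CC1(CO)CO` also gives a limit, > 24000 nM. Compound 3 `CC(C)Nc1nc(N)nc2c1ncn2/C=C1/CC1(CO)CO` likewise gives a limit, > 24000 nM. All three values are therefore limits rather than numbers, one sitting at the limit of > 20000 nM in this assay, at which 1 of the 3 values shown sits, and two at the limit of > 24000 nM in this assay, at which 2 of the 3 values shown sit, and none of the three compounds can be ordered against another.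

Compound 4 `CCCCCCSc1nc(N)nc2c1ncn2/C=C1/CC1(CO)CO` has not been measured in this assay. The change from compound 2 is hexylsulfanyl in place of 2,2,2-trifluoroethoxy on an aromatic carbon. Among the measured compounds shown here, the steps that touch the same aromatic carbon, a step that the two limits leave unreadable from compound 1 to compound 2 and a step that the two limits leave unreadable from compound 2 to compound 3, and the step that the two limits leave unreadable from compound 1 to compound 3 at the neighbouring site, are all unreadable from the limits, so no measured step gives a size or a direction for the exchange of 2,2,2-trifluoroethoxy for hexylsulfanyl.

Compound 4 is accordingly expected to lie near where the series sits, with an estimate of 15000 nM between 4000 nM and 40000 nM. The corresponding expected step of an at least 1.3-fold lower number from compound 2 to compound 4 (0.12 log units; that floor lies within the scatter) carries no direction that the data can support, and a limit-only result is thought likely.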

Compound 4, half-maximal cytotoxic concentration: > 20000 nM
Compound 4 ended at the assay's limit; the forecaster's own chance of this, stated with the estimate: 55%; at least 1.3-fold (0.12 log units) between middle value and limit.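

Compound 4 gives only a limit: the limit of > 20000 nM in this assay, at which 2 of the 4 values shown sit.

Among the compounds shown here, compound 1, compound 2 and compound 3 are limits too, so no step between them and compound 4 can be read in this assay. The compounds shown leave open how hexylsulfanyl, 2,2,2-trifluoroethoxy, methylamino and isopropylamino compare on that aromatic carbon.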